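Fluorophenyl for methoxyphenyl: cytotoxicity of a sulfonamide series

The source may hold more compounds than are shown below. What is called first, only, known or untested is meant among the compounds shown, and "the series" means these compounds.

Compound 1 `O=S(=O)(Nc1ccc(-c2nc3ccccc3o2)cc1)c1ccccc1O`: > 100000 nM
Compound 2 `O=S(=O)(Nc1ccc(-c2nc3ccccc3o2)cc1)c1ccc(Cl)s1`: > 100000 nM
Compound 3 `COc1cccc(S(=O)(=O)Nc2ccc(-c3nc4ccccc4o3)cc2)c1`: > 100000 nM

In an ADME assay on HEK293 cells (Homo sapiens) for cytotoxicity, read by resazurin assay, with a stated time of 48 h (on this read-out higher numbers stand for lower toxicity in this test and lower numbers for higher toxicity in this test), compound 3 gives only a limit, > 100000 nM, not a number. The same holds for its two companions: all three measured values sit at the limit of > 100000 nM in this assay, at which 3 of the 3 values shown sit. As a result, the steps that join them cannot be read in size: a step that the two limits leave unreadable from compound 1 to compound 2, a step that the two limits leave unreadable from compound 1 to compound 3 and a step that the two limits leave unreadable from compound 2 to compound 3 are all left open by the two limits. Compound 3 thus stands nowhere above or below the others; it simply shares the limit with them.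

The next compound, compound 4 `O=S(=O)(Nc1ccc(-c2nc3ccccc3o2)cc1)c1ccc(F)cc1`, differs from compound 3 in one place: 4-fluorophenyl in place of 3-methoxyphenyl on a sulfonyl sulfur. Every measured step in this set touches the group on the sulfonyl sulfur, and none of them shows a readable size, so there is no measured basis for expecting a step beyond the scatter in this assay. Compound 4 is therefore expected to sit at the limit as well, with a step that the limit leaves unreadable from compound 3 to compound 4 estimated as no step beyond the scatter. The estimate for compound 4 in this assay is 200000 nM, expected to lie between 80000 nM and 600000 nM.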

Compound 4, half-maximal cytotoxic concentration: > 100000 nM
Compound 4: only a limit was reported (the forecaster's own chance of this, stated with the estimate: 80%); the middle value lies beyond the limit too.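

No new step can be read between compound 4 and compound 1, compound 2 or compound 3, because all of them stand at the same limit: the limit of > 100000 nM in this assay, at which 4 of the 4 values shown sit. In this assay the compounds shown leave open whether any group on the sulfonyl sulfur gives a readable number.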